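The source may hold more compounds than are shown below. What is called first, only, known or untested is meant among the compounds shown, and "the series" means these compounds.

Compound 3 `CCCCNC(=O)C1=Cc2ccc(OC)cc2OC1c1cc(OC)c(OC)c(OC)c1` gives 25500 nM in a functional assay for inhibition of nuclear factor NF-kappa-B complex (Homo sapiens) (a higher number here means a weaker inhibitor, a lower number a stronger inhibitor), and stands second highest of the three numbers, nearest to compound 1 `COc1ccc2c(c1)OC(c1cc(OC)c(OC)c(OC)c1)C(C(=O)NC(C)(C)C)=C2` at 28400 nM and furthest from compound 2 `CCCC(=O)C1=Cc2ccc(OC)cc2OC1c1cc(OC)c(OC)c(OC)c1` at 11700 nM. Compound 4 `CNC(=O)C1=Cc2ccc(OC)cc2OC1c1cc(OC)c(OC)c(OC)c1` is compound 3 with hydrogen in place of propyl on a saturated chain carbon bound to an amide-type nitrogen. Among the compounds with values here, only one measured step touches the group on the amide-type nitrogen: a 1.1-fold lower number from compound 1 to compound 3 (0.05 log units; within the scatter), which stayed within the scatter. The steps of a 2.4-fold lower number from compound 1 to compound 2 (0.39 log units; beyond the scatter) and a 2.2-fold higher number from compound 2 to compound 3 (0.34 log units; beyond the scatter) exchange the whole carbonyl substituent and bear on this change only indirectly. Shortening the chain on the amide nitrogen is therefore expected to give no step beyond the scatter in this assay, a 1.0-fold lower number from compound 3 to compound 4 (0.01 log units; within the scatter). Compound 4 is estimated at 25000 nM, with a range from 10000 nM to 60000 nM.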

Compound 4, half-maximal inhibitory concentration: > 50000 nM
Compound 4: no number, only a limit (the forecaster's own chance of this, stated with the estimate: 10%); middle value at least 2.0-fold (0.30 log units) from the limit.
By their numbers in this assay, from the lowest: compound 2; then compounds 3 and 1 (each within the scatter of the next). At a limit, above all of these: compound 4.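

In this assay compound 4 reads only as a limit, > 50000 nM. Against the two other amides the floors stay within the scatter, an at least 1.9-fold higher number from compound 3 to compound 4 (0.29 log units; that floor lies within the scatter) and an at least 1.7-fold higher number from compound 1 to compound 4 (0.24 log units; that floor lies within the scatter), so methyl on the amide-type nitrogen is not yet separated from butyl or tert-butyl. Methylamino in place of propyl on the carbonyl carbon does clear the scatter, an at least 4.2-fold higher number from compound 2 to compound 4 (0.63 log units; beyond the scatter), which places compound 4 as weaker than compound 2.

As far as these compounds go, the actual number for compound 4 stays open. So does the reading in this assay for a longer chain such as hexyl, or a terminal amine, on the amide-type nitrogen.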